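Removing the Allyl Group from a Weakly Inhibiting Sulfur

A few compounds are considered here, and "the series" means these few. Any claim that something is new, unique, unknown or untested is made for them only; others in the source may bear on it.

Three compounds that share one fused core were examined in a functional assay for inhibition, with Homo sapiens as the target; on this read-out higher numbers stand for weaker inhibition and lower numbers for stronger inhibition. Compound 1 `Cc1nc(C)n2c(S)nncc12` carries a bare sulfur on that core. In this assay compound 1 reaches only a limit of the assay, > 48000 nM. Compound 2 `C=CCSc1nncc2c(C)nc(C)n12` carries an allyl group on the same sulfur, and in this assay compound 2 gives 59000 nM. Compound 3 `C=CCSc1nncc2c(C)nc(-c3ccccc3)n12` differs from compound 2 in its core by phenyl in place of methyl on an aromatic carbon. In this assay compound 3 likewise reaches only a limit of the assay, > 48000 nM.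

The step that the limit leaves unreadable from compound 2 to compound 1 and the step that the limit leaves unreadable from compound 2 to compound 3 cannot be given a size because of the limit of > 48000 nM in this assay, at which 2 of the 3 values shown sit. All three readings therefore describe very weak inhibition, and no ordering among them can be drawn.

Compound 4 `Cc1nc(-c2ccccc2)n2c(S)nncc12` has not yet been measured. It differs from compound 3 by hydrogen in place of allyl on a sulfur. This is the same change that separates compound 2 from compound 1, namely (hydrogen in place of allyl on a sulfur), made at the same place. An expected step that the limit leaves unreadable from compound 3 to compound 4 rests on compound 2 having given 59000 nM with the allyl group still in place. This expectation rests equally on compound 1, which after removal of that group reached only a limit of the assay, > 48000 nM. In this assay compound 4 is expected near 80000 nM, most likely between 40000 nM and 200000 nM, and the assay is expected quite possibly to report only a limit once more.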

Compound 4, half-maximal inhibitory concentration: > 48000 nM
Compound 4 gave a limit, no number (the forecaster's own chance of this, stated with the estimate: 85%); the middle value does not contradict the limit.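

The change from compound 3 to compound 4 cannot be given a size in this assay, since neither compound yields an actual number: the limit of > 48000 nM in this assay, at which 3 of the 4 values shown sit.

As far as these compounds go, whether the allyl group on the sulfur, or phenyl in place of methyl on the core, makes any difference to inhibition stays open, as does the true strength of compound 1, compound 3 and compound 4.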